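The source may report more compounds than this note shows. Statements on the series, on what has been measured and on what is new or still open speak of the compounds shown alone.

Measured so far in a functional assay on NCI-H322M cells (Homo sapiens) for inhibition, read by sulforhodamine B assay, with a stated time of 48 h; a higher number here means that more compound is tolerated, a lower number that less compound is tolerated:
compound 1, `COc1ccc(CNc2nc3cc(N)cc(N)c3nc2-c2ccccc2)cc1OC`: 100000 nM
compound 2, `COc1cc(CNc2nc3cc(N)cc(N)c3nc2-c2ccccc2)cc(OC)c1OC`: < 50200 nM, a limit of the assay
compound 3, `COc1ccc(Sc2nc3cc(N)cc(N)c3nc2-c2ccccc2)cc1`: < 100000 nM, a limit of the assay

Compound 3 stands at a limit: its reading of < 100000 nM is a limit of the assay and not a number, matching (the limit of < 100000 nM in this assay, at which 1 of the 3 values shown sits). Going by the values given here, the one full number in the set belongs to compound 1; the reading of compound 2 is also a limit, matching (the limit of < 50200 nM in this assay, at which 1 of the 3 values shown sits). Among the compounds with values here, the only step within the measured set is an at least 1.9-fold lower number from compound 1 to compound 2 (0.29 log units; that floor lies within the scatter), and its floor lies within the scatter.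

Compound 4, `Nc1cc(N)c2nc(-c3ccccc3)c(Sc3ccc(F)cc3)nc2c1`, differs from compound 3 by fluoro in place of methoxy on an aromatic carbon. No measured step concerns a fluoro group or the sulfur-linked phenyl, so nothing shown bears directly on this change. The measured step from compound 1 to compound 2 touches a methoxy group but on the benzylamino ring and within the scatter, so it gives no direction. The expectation for this assay is therefore a step of no more than the usual scatter, a step that the limit leaves unreadable from compound 3 to compound 4. Compound 4 is estimated at 70000 nM, with a range from 25000 nM to 100000 nM, and a reading that is again only a limit is quite possible.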

Compound 4, concentration lethal to 50% of the cells: 70800 nM
Compound 4: the middle estimate sits 1.0-fold (0.00 log units) below what was measured; measured number inside the range.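

Going by these compounds alone, compound 3 reads < 100000 nM, which is a limit of the assay and not a number, so no step from compound 3 to compound 4 can be read. The compounds shown leave open whether going from (4-methoxyphenyl)sulfanyl to (4-fluorophenyl)sulfanyl changes the number in this assay at all, and in which direction.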